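Swapping Ethyl for Carboxymethyl on Compound 1

The source may report more compounds than this note shows. Statements on the series, on what has been measured and on what is new or still open speak of the compounds shown alone.

- compound 1 `CCn1nc(CC(=O)Nc2ccc(OC(F)(F)F)c(Cl)c2)c2ccccc2c1=O`: 5.42
- compound 2 `O=C(O)Cn1nc(Cc2nc3cc(Cl)c(OCC(F)F)cc3[nH]2)c2ccccc2c1=O`: 1.97
- compound 3 `COc1cc(OC)c(NC(=O)Cn2nc(CC(=O)O)c3ccccc32)cc1Cl`: 1.86

All three compounds have been measured in a physicochemical assay for lipophilicity, at pH 7.4; on this read-out higher numbers stand for higher lipophilicity and lower numbers for lower lipophilicity. In this assay compound 1 stands highest of the three at 5.42, and its gaps to compound 2 and compound 3 both lie beyond the usual scatter of repeated measurements.

The next compound to be measured is compound 4 `O=C(O)Cn1nc(CC(=O)Nc2ccc(OC(F)(F)F)c(Cl)c2)c2ccccc2c1=O`. It differs from compound 1 in one place, with carboxy in place of methyl on a saturated chain carbon bound to an aromatic nitrogen. The same change can also be read as ethyl to carboxymethyl.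

Among the compounds with values here, no measured pair shows this change directly, so the available guide is only rough. Compound 2 at 1.97 and compound 3 at 1.86 both carry a carboxy group, while compound 1 carries none. Both also differ from compound 1 elsewhere in their structures, which limits the comparison.

A large downward step in this assay, well beyond the scatter, is expected, with an estimated size of a number 3.22 log units lower from compound 1 to compound 4 (beyond the scatter). For compound 4 the estimated value is 2.2, with an expected range from 1.5 to 3.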

Compound 4, distribution coefficient: 2.92
Beside the measured number, compound 4's estimate is 0.72 log units below it; the range from low to high includes it.
By their numbers in this assay, from the lowest: compounds 3 and 2 (each within the scatter of the next); then compound 4; then compound 1.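

In this assay, the change of carboxy in place of methyl, on a saturated chain carbon bound to an aromatic nitrogen, can now be read directly as a number 2.50 log units lower from compound 1 to compound 4 (beyond the scatter) and counts as a large step. The earlier compounds shown here that carry a carboxy group also differ from compound 1 elsewhere in their structures, so they could not separate this change from the others, whereas here everything else in compound 1 stays the same and the whole step belongs to this single place. Nothing shown here gives a measured reason for the size of this step.

As far as these compounds go, this is still one matched pair on one core, so it remains open whether the same change would give a step of similar size on a different core or at another place on this one. Also open, from the compounds shown here alone, is how the number would respond to an amine or a methyl ester in place of the carboxy group, or to a longer chain between the aromatic nitrogen and the carboxy group.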